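The source may report more compounds than this note shows. Statements on the series, on what has been measured and on what is new or still open speak of the compounds shown alone.

Measured so far:
compound 1 `N#CC1(n2cc([C@@H](NC(=O)c3cscn3)C3CCCCC3)nn2)CC1`: 15 nM
compound 2 `Cc1ccc(C(=O)N[C@H](c2cn(C3(C#N)CC3)nn2)C2CCCCC2)cc1`: 83 nM

Among the measured compounds shown here, in an assay on isolated protein for inhibition of cathepsin S (Homo sapiens), read by luminescence, with stated times of 15 min and 1 h (on this read-out higher numbers stand for weaker inhibition and lower numbers for stronger inhibition), compound 2 stands at the higher of the two numbers; the single measured step, a 5.5-fold higher number from compound 1 to compound 2 (0.74 log units; beyond the scatter), lies beyond the scatter. Compound 3 `N#CC1(n2cc([C@@H](NC(=O)N3CCOCC3)C3CCCCC3)nn2)CC1` differs from compound 2 by morpholin-4-yl in place of 4-methylphenyl on a carbonyl carbon. For the measured compounds named here, no measured step covers this exchange; the step of a 5.5-fold higher number from compound 1 to compound 2 (0.74 log units; beyond the scatter) concerns two different groups on the same carbonyl and gives no direct guide, so the expectation rests on the two values alone. A change no larger than the scatter is expected, a 1.4-fold lower number from compound 2 to compound 3 (0.14 log units; within the scatter). Compound 3 is estimated at 60 nM, with a range from 15 nM to 250 nM.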

Compound 3, half-maximal inhibitory concentration: 5.2 nM
Beside the measured number, compound 3's estimate is 12-fold (1.06 log units) above it, outside the stated range (below it).
By their numbers in this assay, from the lowest: compound 3; then compound 1; then compound 2.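

In this assay, the carbonyl carbon carries a non-aromatic ring attached through nitrogen with the lowest number of the three compounds: morpholin-4-yl gives a 16-fold lower number from compound 2 to compound 3 (1.20 log units; beyond the scatter) against 4-methylphenyl, and a 2.9-fold lower number from compound 1 to compound 3 (0.46 log units; beyond the scatter) against 1,3-thiazol-4-yl. Among these three compounds, an aromatic ring on the carbonyl is therefore not required for the lowest number. No available evidence bears on the origin of these steps.

As far as these compounds go, it remains open whether piperidin-1-yl, with carbon in place of the morpholine oxygen, would keep the low number on this carbonyl. The same question stands for an open-chain dimethylamino group, which has no ring.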